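Methyl in place of hydrogen: from compound 1 to compound 4

This account rests on a few compounds, and the source may have more. Where it says the series, first, only, none or still open, it means among the compounds named here.

Compound 1, `O=C(Nc1nnc(-c2ccc(Cl)cc2)s1)c1ccccc1`: in a functional assay on the whole organism (integument) for inhibition, with Chilo suppressalis as the target, read by scintillation counting, with a stated time of 72 h (a higher number here means a weaker inhibitor, a lower number a stronger inhibitor), compound 1 gives > 5010 nM, which is a limit of the assay.
Compound 2, `O=C(Nc1nnc(-c2ccc(Cl)cc2)s1)c1c(Cl)cccc1Cl`: in this assay compound 2 gives 380 nM.
Compound 3, `O=C(Nc1nnc(-c2ccc(Cl)cc2)s1)c1ccccc1Br`: in this assay compound 3 gives > 5010 nM, which is a limit of the assay.

Compound 1 stands at the limit of this assay, so no number is known for it. Compound 4, `Cc1ccccc1C(=O)Nc1nnc(-c2ccc(Cl)cc2)s1`, is not yet measured. It differs from compound 1 by methyl in place of hydrogen on an aromatic carbon, a small change on the phenyl ring that turns phenyl into 2-methylphenyl.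

Among the measured compounds shown here, the one measured step on that ring, a step that the two limits leave unreadable from compound 1 to compound 3, cannot be sized, since both its ends are limits. For the measured compounds named here, compound 2 carries two chloro groups on the same ring and is the only compound with a measured number. Going by the values given here, the nearest guide is therefore (the limit of > 5010 nM in this assay, at which 2 of the 3 values shown sit), and a single methyl is more like the single bromo of compound 3 than the pair of chloro groups of compound 2.

Compound 4 is thus expected to stay near the limit, with a step that the limit leaves unreadable from compound 1 to compound 4 as the expected step. The estimate for compound 4 is 6000 nM, in a range from 1500 nM to 30000 nM.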

Compound 4, half-maximal inhibitory concentration: 158 nM
Compound 4: the middle estimate sits 38-fold (1.58 log units) above what was measured; measured number below the stated range.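

In this assay, adding one methyl to the phenyl ring gives an at least 31-fold lower number from compound 1 to compound 4 (1.50 log units; beyond the scatter), so this position responds strongly to a single small group. Exchanging bromo for methyl at the same position gives an at least 31-fold lower number from compound 3 to compound 4 (1.50 log units; beyond the scatter), so the two single groups are not interchangeable here, and the identity of the group matters and not merely the presence of one. Both steps are only minimum sizes and the step between the bromo and unsubstituted compounds cannot be read at all, because compound 1 and compound 3 each stand at a limit: the limit of > 5010 nM in this assay, at which 2 of the 4 values shown sit.

The compounds shown do not tell how ethyl, methoxy or an amine would read at this position. They also leave open whether a methyl on another carbon of the same ring would lower the number in the same way.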